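A few compounds are considered here, and "the series" means these few. Any claim that something is new, unique, unknown or untested is made for them only; others in the source may bear on it.

In a functional assay for agonist activity at G protein-coupled receptor 88 (Homo sapiens), read by HTRF and cAMP accumulation (on this read-out lower numbers stand for an effect already at smaller amounts and higher numbers for an effect only at larger amounts of compound), compound 1 `CC[C@H](C)[C@H](N)CN(C(=O)[C@@H]1C[C@H]1c1ccccc1)c1ccc(-c2ccc(OC(C)C)cc2)cc1` gives 72 nM, and compound 2 `CC[C@H](C)[C@H](N)CN(C(=O)[C@@H]1C[C@H]1c1ccccc1)c1ccc(-c2ccc(CCC(=O)OC)cc2)cc1` gives 110 nM. Going by the values given here, of the two numbers measured so far, that of compound 2 is the higher, yet the step of a 1.5-fold higher number from compound 1 to compound 2 (0.18 log units; within the scatter) lies within the scatter, so the two compounds cannot really be told apart. Compound 3 `CC[C@H](C)[C@H](N)CN(C(=O)[C@@H]1C[C@H]1c1ccccc1)c1ccc(-c2ccc(CNC)cc2)cc1` departs from compound 2 by methylamino in place of (methoxycarbonyl)methyl on a saturated chain carbon bound to an aromatic carbon. The one measured step, an exchange of isopropoxy for 2-(methoxycarbonyl)ethyl on the aromatic carbon, left the number within the scatter; no measured step exchanges an ester chain for a methylamino group, so the change to compound 3 has no close precedent among these compounds. The step from compound 2 to compound 3 is therefore estimated as a 1.1-fold higher number from compound 2 to compound 3 (0.04 log units; within the scatter), with a broad range on either side. Compound 3 is expected to give 120 nM in this assay, between 40 nM and 400 nM.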

Compound 3, half-maximal effective concentration: 6400 nM
Compound 3: middle estimate off by 53-fold (1.73 log units), on the low side, outside the stated range (above it).
By their numbers in this assay, from the lowest: compounds 1 and 2 (each within the scatter of the next); then compound 3.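

In this assay, isopropoxy and 2-(methoxycarbonyl)ethyl on the aromatic carbon could not be told apart, but compound 3 shows that this position is not indifferent to what it carries: methylamino in place of (methoxycarbonyl)methyl gives a 58-fold higher number from compound 2 to compound 3 (1.76 log units; beyond the scatter), and (methylamino)methyl in place of isopropoxy gives an 89-fold higher number from compound 1 to compound 3 (1.95 log units; beyond the scatter). Both steps are large and beyond the scatter, so among these three compounds the much higher number goes with (methylamino)methyl alone. Nothing available here bears on what lies behind this rise.

The exchange both shortens the chain and brings in a nitrogen, and the compounds shown cannot separate these two changes. As far as these compounds go, a longer chain ending in methylamino, or a methoxymethyl group, would bear on that question, and a carboxylic acid at the end of the chain remains equally open.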